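The compounds below may be only part of what the source reports. "The series", "measured", "known", "first", "only" and "open" are said of these compounds alone.

In a functional assay on MCF7 cells (Homo sapiens) for inhibition, read by MTT assay, with a stated time of 48 h (on this read-out lower numbers stand for stronger inhibition and higher numbers for weaker inhibition), compound 1 `COc1cc2ccc(=O)oc2cc1OCCCCOc1no[n+]([O-])c1S(=O)(=O)c1ccccc1` gives 3040 nM. Compound 2 `COc1cc2cc(NC(C)=O)c(=O)oc2cc1OCCCCOc1no[n+]([O-])c1S(=O)(=O)c1ccccc1` gives 3440 nM in this assay; its number sits alongside that of compound 1, since a 1.1-fold higher number from compound 1 to compound 2 (0.05 log units; within the scatter) is within the scatter. Compound 3 `COc1cc2cc(N)c(=O)oc2cc1OCCCCOc1no[n+]([O-])c1S(=O)(=O)c1ccccc1` differs from compound 2 by hydrogen in place of acetyl on a nitrogen on an aromatic ring. Going by the values given here, the only step that bears on this change is a 1.1-fold higher number from compound 1 to compound 2 (0.05 log units; within the scatter), which was within the scatter, so no step beyond the scatter is expected in this assay, in either direction. Compound 3 is therefore estimated at 3200 nM, between 1500 nM and 7000 nM, an expected step of a 1.1-fold lower number from compound 2 to compound 3 (0.03 log units; within the scatter).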

Compound 3, half-maximal inhibitory concentration: 2280 nM
Beside the measured number, compound 3's estimate is 1.4-fold (0.15 log units) above it, within the range that was stated.
By their numbers in this assay, from the lowest: compounds 3, 1 and 2 (each within the scatter of the next).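

In this assay, hydrogen in place of acetyl on the nitrogen gives a 1.5-fold lower number from compound 2 to compound 3 (0.18 log units; within the scatter), and amino in place of hydrogen on the aromatic carbon gives a 1.3-fold lower number from compound 1 to compound 3 (0.12 log units; within the scatter). This aromatic carbon has now carried hydrogen, acetamido and amino with no step beyond the scatter, so the free amino group separates itself from neither of the other two. No evidence is available that bears on this result. Going by these compounds, whether a carboxylic acid, a dimethylamino group or a longer acyl chain on this nitrogen or carbon would move the number beyond the scatter remains open.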